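This account rests on a few compounds, and the source may have more. Where it says the series, first, only, none or still open, it means among the compounds named here.

Compound 1 `CSc1nccc2c1ncn2[C@H]1C[C@H](O)[C@@H](CO)O1` and compound 2 `OC[C@H]1O[C@@H](n2cnc3c(SCc4ccccc4)nccc32)C[C@@H]1O` share one core and differ only in the group on sulfur. In a functional assay on EL4 cells (Mus musculus) for inhibition, tested at 100 uM (a lower number here means less inhibition, a higher number more inhibition at the concentration tested (going by the name of the read-out)), compound 1 gives < 5%, which is a limit of the assay rather than a number. In this assay, for the measured compounds named here, compound 2 gives 11%, the only number among the values shown. Going by the values given here, the single measured step, a number at least 6 percentage points higher from compound 1 to compound 2 (that floor lies within the scatter), rests on (the limit of < 5% in this assay, at which 1 of the 2 values shown sits). Compound 3 `OC[C@H]1O[C@@H](n2cnc3c(Cl)nccc32)C[C@@H]1O` differs by chloro in place of benzylsulfanyl on an aromatic carbon. Among the compounds with values here, no measured step removes the sulfur group entirely, so that step offers only a loose guide. Compound 3 is expected to give about 5%, between 0% and 15%. The expected step of a number 6 percentage points lower from compound 2 to compound 3 (within the scatter) stays within the scatter.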

Compound 3, a percentage reported as inhibition, at one concentration (the size of the read-out at that concentration, not a potency): < 5%
Compound 3: no number, only a limit; the forecaster's own chance of this, stated with the estimate: 50%; the middle value lies on the limit itself.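

In this assay, chloro in place of benzylsulfanyl on this aromatic carbon, next to the ring nitrogen, gives a number at least 6 percentage points lower from compound 2 to compound 3 (that floor lies within the scatter). The step between compound 1 and compound 3 cannot be read, since both values are limits of the assay and not numbers. Compound 2 remains the only one with a number, so no firm size can yet be put on any change at this position: the limit of < 5% in this assay, at which 2 of the 3 values shown sit.

From the compounds shown here alone, what an amine at this aromatic carbon, or a longer chain on the sulfur, would give stays open. So does whether any group here can move the read-out clearly beyond the scatter.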